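The source may hold more compounds than are shown below. What is called first, only, known or untested is meant among the compounds shown, and "the series" means these compounds.

Measured in a functional assay on Ehrlich cells (Mus musculus) for antiproliferative activity, read by trypan blue exclusion, with a stated time of 2 h; on this read-out higher numbers stand for weaker inhibition and lower numbers for stronger inhibition:
compound 1 `N#CC1=C(N)N(c2ccc(S(N)(=O)=O)cc2)C2=C(C(=O)CCC2)C1c1ccc(O)cc1`: 3 ug/mL
compound 3 `COc1ccc(C2C(C#N)=C(N)N(c3ccc(S(N)(=O)=O)cc3)C3=C2C(=O)CCC3)cc1`: 25 ug/mL
compound 2 `COc1ccccc1C1C(C#N)=C(N)N(c2ccc(S(N)(=O)=O)cc2)C2=C1C(=O)CCC2`: reported only as a limit, > 100 ug/mL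

Compound 1 holds the lowest of the two numbers in this assay; its nearest neighbour is compound 3, with an 8.3-fold higher number from compound 1 to compound 3 (0.92 log units; beyond the scatter). The value of compound 2 is a limit of the assay (the limit of > 100 ug/mL in this assay, at which 1 of the 3 values shown sits), so only a bound is known for it.

Compound 4 `N#CC1=C(N)N(c2ccc(S(N)(=O)=O)cc2)C2=C(C(=O)CCC2)C1c1cccs1` is not yet measured. It differs from compound 1 by thiophen-2-yl in place of 4-hydroxyphenyl on a saturated ring carbon. Within the data shown here, three measured steps bear on this change. Capping the hydroxyl, methyl in place of hydrogen on an oxygen on an aromatic ring, gives an 8.3-fold higher number from compound 1 to compound 3 (0.92 log units; beyond the scatter). Exchanging the whole 4-hydroxyphenyl for 2-methoxyphenyl on a saturated ring carbon gives an at least 33-fold higher number from compound 1 to compound 2 (1.52 log units; beyond the scatter), and going from 2-methoxyphenyl to 4-methoxyphenyl on that carbon gives an at least 4.0-fold lower number from compound 2 to compound 3 (0.60 log units; beyond the scatter). Thiophen-2-yl, like 4-methoxyphenyl, brings no hydrogen-bond donor, so a modest rise in number, beyond the scatter, is expected: a 6.7-fold higher number from compound 1 to compound 4 (0.82 log units; beyond the scatter). Compound 4 is therefore estimated at 20 ug/mL, with a range of 5 ug/mL to 80 ug/mL.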

Compound 4, half-maximal inhibitory concentration: 5 ug/mL
The estimate for compound 4 lay 4.0-fold (0.60 log units) above the measured number; the measured number falls inside the stated range.
By their numbers in this assay, from the lowest: compounds 1 and 4 (each within the scatter of the next); then compound 3. At a limit, above all of these: compound 2.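

In this assay, a 1.7-fold higher number from compound 1 to compound 4 (0.22 log units; within the scatter), so thiophen-2-yl, with 0 hydrogen-bond donors, serves on this saturated ring carbon as well as 4-hydroxyphenyl, and a hydroxyl is not required there. Against 4-methoxyphenyl, a 5.0-fold lower number from compound 3 to compound 4 (0.70 log units; beyond the scatter), so the link between the free hydroxyl and a low number seen with compound 1 and compound 3 does not extend to thiophen-2-yl. Compound 2 stands at a limit, so an at least 20-fold lower number from compound 2 to compound 4 (1.30 log units; beyond the scatter) is a bound only: the limit of > 100 ug/mL in this assay, at which 1 of the 4 values shown sits.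

From the compounds shown here alone, whether the number stays this low with furan-2-yl, thiophen-3-yl or unsubstituted phenyl on this carbon remains open. So does the outcome with a non-aromatic group such as cyclohexyl, or with an amine or carboxylic acid on the aromatic ring.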